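Flipping the Drawn Hydrazone Geometry of Compound 3

A few compounds are considered here, and "the series" means these few. Any claim that something is new, unique, unknown or untested is made for them only; others in the source may bear on it.

Compound 1 `C/C(=N\NC(=S)Nc1ccccc1[N+](=O)[O-])c1ccccn1` in a functional assay on T98G cells (Homo sapiens) for cytotoxicity, read by MTT assay, with a stated time of 48 h (on this read-out higher numbers stand for weaker inhibition and lower numbers for stronger inhibition), gives 6.61 nM.
Compound 2 `C/C(=N/NC(=S)Nc1ccccc1F)c1ccccn1` in this assay gives 3.1 nM.
Compound 3 `C/C(=N/NC(=S)Nc1ccccc1Cl)c1ccccn1` in this assay gives 1.1 nM.

Among the measured compounds shown here, compound 3 gives the lowest number of the three, and its steps to both others lie beyond the scatter; the only single-point step among them, a 2.8-fold lower number from compound 2 to compound 3 (0.45 log units; beyond the scatter), is a modest one. Compound 4 `C/C(=N\NC(=S)Nc1ccccc1Cl)c1ccccn1` has not yet been measured. It differs from compound 3 in this way: the two compounds have the same atoms and bonds and differ only in configuration as drawn: 1 of 1 stereo elements differ; a double bond is drawn Z in compound 3 and E in compound 4. For the measured compounds named here, no measured step changes only the drawn configuration, so nothing among the steps bears directly on this change. Going by the values given here, the one other compound drawn in the same configuration as compound 4 is compound 1, which differs from compound 3 in the aromatic substituent as well, so its value tells little on its own. Among the compounds with values here, with no step to lean on, the expected step of a 1.4-fold higher number from compound 3 to compound 4 (0.13 log units; within the scatter) is small and within the scatter, since the atoms and bonds are unchanged. Compound 4 is therefore estimated at 1.5 nM, with a range from 0.5 nM to 5 nM.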

Compound 4, half-maximal inhibitory concentration: 1.1 nM
Estimate against measurement, compound 4: 1.4-fold (0.13 log units) above; measured number inside the range.
By their numbers in this assay, from the lowest: compounds 3 and 4 (each within the scatter of the next); then compound 2; then compound 1.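

In this assay, among the compounds shown here, the record shows no change at the digits printed from compound 3 to compound 4 (within the scatter), and this pair gives the first reading on the drawn configuration of the double bond alone: the fact that compounds 3 and 4 differ only in the configuration as drawn. For the compounds shown here, compound 4 also gives the first substituent comparison among compounds drawn in this configuration, a 6.0-fold lower number from compound 1 to compound 4 (0.78 log units; beyond the scatter). With a 2.8-fold lower number from compound 2 to compound 3 (0.45 log units; beyond the scatter), this means chloro gives the lower number in both drawn configurations, though against a different partner in each.

The compounds shown leave open whether the drawn configuration counts for as little with fluoro or nitro on the aromatic carbon, as each of these appears here in one configuration only. They also leave open how a bromo or methoxy group in place of the chloro would read in either configuration.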